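This account rests on a few compounds, and the source may have more. Where it says the series, first, only, none or still open, it means among the compounds named here.

Measured compounds:
Compound 1, `CC(C)N(Cc1cccc(OCCCCCC(=O)O)c1)C(=O)c1ccccc1`, in an ADME assay on Raji cells (Homo sapiens) for cytotoxicity, read by CellTiter-Glo and resazurin assay, with a stated time of 72 h (a lower number here means that less compound is needed, a higher number that more compound is needed for the effect), gives > 26000 nM, a limit of the assay rather than a number.
Compound 2, `CC(=O)Nc1cccc(-c2ccc(C(=O)N(Cc3cccc(OCCCCCC(=O)O)c3)C(C)C)cc2)c1`, in this assay gives > 26000 nM, again a limit.
Compound 3, `CCOC(=O)CCCCCOc1cccc(CN(C(=O)c2ccc(-c3cccc(NC(C)=O)c3)cc2)C(C)C)c1`, in this assay gives > 26000 nM, also a limit.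

Among the compounds with values here, compound 3 thus stands exactly where every compound so far stands: all three values sit at the limit of > 26000 nM in this assay, at which 3 of the 3 values shown sit, so no compound has yet given a numbered value, and compound 3 cannot be set apart from the others. The two steps among the measured compounds, a step that the two limits leave unreadable from compound 1 to compound 2 and a step that the two limits leave unreadable from compound 2 to compound 3, are unreadable, since both ends of each are limits.

Compound 4, `CCOC(=O)CCCCCOc1cccc(CN(C(=O)c2ccc(-c3ccc4[nH]ccc4c3)cc2)C(C)C)c1`, differs from compound 3 in one place: 1H-indol-5-yl in place of 3-acetamidophenyl on an aromatic carbon. Within the data shown here, no measured step covers this change, and the steps that do exist carry no size to borrow. Among the measured compounds shown here, the only guide is that three compounds of this shared core, compound 3 among them, all sit at the limit. Compound 4 is therefore expected to stay near that limit too, with the step that the limit leaves unreadable from compound 3 to compound 4 expected to be small. The estimate for compound 4 in this assay is 30000 nM, with a range from 10000 nM to 100000 nM, and most likely the assay will again report only a limit.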

Compound 4, half-maximal effective concentration: > 26000 nM
Compound 4: no number, only a limit; the forecaster's own chance of this, stated with the estimate: 75%; the middle value does not contradict the limit.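

In this assay compound 4 gives > 26000 nM as a limit of the assay and not a number. Within the data shown here, compound 3 also stands at a limit, so no step from compound 3 to compound 4 can be read, and all values remain at one point: the limit of > 26000 nM in this assay, at which 4 of the 4 values shown sit.

Still open, on these data alone, is whether in this assay any compound built on the shared core gives a numbered value rather than a limit.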